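Amide aryl variation on the shared core: compound 4

The compounds below may be only part of what the source reports. "The series", "measured", "known", "first", "only" and "open" are said of these compounds alone.

For the measured compounds named here, compound 3 `Cc1cc(Cl)ccc1C(=O)Nc1ccc(Cl)c(-c2nnc3c(Cl)cccn23)c1` carries the only readable number in this set; in a functional assay on MDA-MB-468 cells (Homo sapiens) for antiproliferative activity, read by MTT assay, with a stated time of 72 h (on this read-out lower numbers stand for stronger inhibition and higher numbers for weaker inhibition), compound 3 gives 34300 nM. Compound 1 `O=C(Nc1ccc(Cl)c(-c2nnc3c(Cl)cccn23)c1)c1ccc(C(F)(F)F)cc1Cl` reaches only a limit of this assay, > 100000 nM. Compound 2 `O=C(Nc1ccc(Cl)c(-c2nnc3c(Cl)cccn23)c1)c1ccc(F)cc1Cl` likewise gives only a limit of this assay, > 100000 nM. The step that the two limits leave unreadable from compound 1 to compound 2 thus cannot be read, and the limit of > 100000 nM in this assay, at which 2 of the 3 values shown sit, marks where both sit. The change to compound 4 `O=C(Nc1ccc(Cl)c(-c2nnc3c(Cl)cccn23)c1)c1ccccc1Cl` is 2-chlorophenyl in place of 4-chloro-2-methylphenyl on a carbonyl carbon. The nearest measured step is an at least 2.9-fold lower number from compound 2 to compound 3 (0.46 log units; beyond the scatter), an exchange of the aryl on the same carbonyl carbon; compound 4 resembles compound 2 more closely, lacking only the fluoro. A weaker number is therefore expected, a 2.0-fold higher number from compound 3 to compound 4 (0.31 log units; beyond the scatter), with a limit a real possibility. Compound 4 is estimated at 70000 nM (range 20000 nM to 300000 nM).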

Compound 4, half-maximal inhibitory concentration: > 100000 nM
Compound 4: a limit, no number; the forecaster's own chance of this, stated with the estimate: 45%; middle value at least 1.4-fold (0.15 log units) from the limit.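

In this assay, 2-chlorophenyl in place of 4-chloro-2-methylphenyl on the carbonyl carbon gives an at least 2.9-fold higher number from compound 3 to compound 4 (0.46 log units; beyond the scatter). Of the aryl groups shown on this carbonyl carbon, 4-chloro-2-methylphenyl alone gives a readable number. The steps among compound 1, compound 2 and compound 4 cannot be read, and these compounds share one limit: the limit of > 100000 nM in this assay, at which 3 of the 4 values shown sit.

Which part of 4-chloro-2-methylphenyl the readable number depends on remains open. Also open, from the compounds shown here alone, is whether an amine or a carboxylic acid on this aryl ring would give a readable number.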